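Swapping Chloro for Fluoro on a Weakly Cytotoxic Hydrazone

A few compounds are considered here, and "the series" means these few. Any claim that something is new, unique, unknown or untested is made for them only; others in the source may bear on it.

For the measured compounds named here, compound 3 `O=C(CSc1ncccn1)N/N=c1/scc(-c2ccc(Cl)cc2)n1-c1ccccc1` gives 91.1% in a functional assay on C6 cells (Rattus norvegicus) for cytotoxicity, read by MTT assay, with a stated time of 24 h, tested at 25 ug/mL (on this read-out higher numbers stand for a weaker effect at the one concentration tested and lower numbers for a stronger effect), the highest of the three numbers known so far. Compound 1 `Cc1nnc(SCC(=O)N/N=c2/scc(-c3ccc(F)cc3)n2-c2ccccc2)s1` gives 50.1% and compound 2 `Cc1nnc(SCC(=O)N/N=c2/scc(-c3ccc(Cl)cc3)n2-c2ccccc2)s1` gives 53.3% in this assay, both beyond the scatter from compound 3. Compound 4 `O=C(CSc1ncccn1)N/N=c1/scc(-c2ccc(F)cc2)n1-c1ccccc1` differs from compound 3 by fluoro in place of chloro on an aromatic carbon. The same exchange, run the other way, is already known: a number 3.2 percentage points higher from compound 1 to compound 2 (within the scatter). The large step of a number 37.8 percentage points higher from compound 2 to compound 3 (beyond the scatter) concerns a different part of the molecule and does not bear on this change. Compound 4 is therefore expected to lie close to compound 3, a step of a number 3.1 percentage points lower from compound 3 to compound 4 (within the scatter) that stays within the scatter, with an estimate of 88% and a range from 75% to 100%.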

Compound 4, a percentage reported as activity, at one concentration (the size of the read-out at that concentration, not a potency): 63.9%
Estimate against measurement, compound 4: 24.1 percentage points above; the measured number lies below the stated range.
By their numbers in this assay, from the lowest: compounds 1 and 2 (each within the scatter of the next); then compound 4; then compound 3.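

With the pyrimidin-2-yl group on the sulfur, fluoro in place of chloro on the aromatic carbon is not a silent exchange in this assay: a number 27.2 percentage points lower from compound 3 to compound 4 (beyond the scatter). The effect of this change therefore depends on the core: the same change on two cores in this assay, a number 3.2 percentage points higher (within the scatter) from compound 1 to compound 2 and a number 27.2 percentage points higher (beyond the scatter) from compound 4 to compound 3, 24 percentage points apart, beyond the scatter of two such steps Pyrimidin-2-yl in place of 5-methyl-1,3,4-thiadiazol-2-yl still leaves a number 13.8 percentage points higher from compound 1 to compound 4 (beyond the scatter) with fluoro, a smaller step than with chloro: the same change on two cores in this assay, a number 37.8 percentage points higher (beyond the scatter) from compound 2 to compound 3 and a number 13.8 percentage points higher (beyond the scatter) from compound 1 to compound 4, 24 percentage points apart, beyond the scatter of two such steps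

The compounds shown leave open how a bromo or a methoxy group at this position would behave on either core. They also do not tell why the two cores respond differently.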